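A few compounds are considered here, and "the series" means these few. Any claim that something is new, unique, unknown or untested is made for them only; others in the source may bear on it.

Measured so far: compound 1 `C=C1C(=O)N(c2ccccc2)N(c2ccccc2)C1CC` with 14900 nM; compound 2 `C=C1C(=O)N(c2ccccc2)N(C)C1CC` with 576000 nM; compound 3 `C=C1C(=O)N(c2ccccc2)N(C)C1C` with 412000 nM.

In a functional assay on NALM-6 cells (Homo sapiens) for inhibition, read by MTT assay, with a stated time of 48 h (on this read-out lower numbers stand for stronger inhibition and higher numbers for weaker inhibition), compound 2 gives the highest number of the three: compound 3 sits close to it, within the usual scatter, while compound 1 sits far lower, a gap that is beyond the scatter. Compound 4 `C=C1C(=O)N(c2ccccc2)N(C)C1CCCCCCCCC` differs from compound 2 by heptyl in place of hydrogen on a saturated chain carbon, two bonds along the chain from a saturated ring carbon. Of the measured steps, only the change on the chain bears on this, and that step, a 1.4-fold lower number from compound 2 to compound 3 (0.15 log units; within the scatter), stayed within the scatter. The large step of a 39-fold higher number from compound 1 to compound 2 (1.59 log units; beyond the scatter) concerns the amine nitrogen, not the chain, so it carries little weight here. The expected change is therefore small, a 1.9-fold lower number from compound 2 to compound 4 (0.28 log units; within the scatter). Compound 4 is estimated at 300000 nM, between 80000 nM and 1000000 nM.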

Compound 4, half-maximal inhibitory concentration: 57500 nM
Compound 4: the middle estimate sits 5.2-fold (0.72 log units) above what was measured; the measured number lies below the stated range.
By their numbers in this assay, from the lowest: compound 1; then compound 4; then compounds 3 and 2 (each within the scatter of the next).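

In this assay, heptyl at this place gives a 10-fold lower number from compound 2 to compound 4 (1.00 log units; beyond the scatter) and so shows that this chain can move the number beyond the scatter. The earlier step on the chain, a 1.4-fold lower number from compound 2 to compound 3 (0.15 log units; within the scatter), gave no sign of this. No evidence shown explains the drop.

Going by these compounds, it remains open whether a shorter pentyl chain gives part of this change, whether a longer chain gives more, and whether an amine or a carboxylic acid at the chain end preserves it. On these data alone, the same change with phenyl on the amine nitrogen also remains open.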